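The source may hold more compounds than are shown below. What is called first, only, known or untested is meant among the compounds shown, and "the series" means these compounds.

In a functional assay on HepG2 cells (Homo sapiens) for antiproliferative activity, read by MTT assay, with a stated time of 48 h (a higher number here means a weaker inhibitor, a lower number a stronger inhibitor), compound 3 (`COc1ccc(/C=C/c2cc(OC)cc(OC)c2/C=C/C(=O)c2cccc(OC)c2)cc1`) gives 11.6 ug/mL and so stands level with compound 1 (`CCCCCCCCCCCCOc1ccc(C(=O)/C=C/c2c(/C=C/c3ccc(OC)cc3)cc(OC)cc2OC)cc1`), which gives 11.6 ug/mL as well, while compound 2 (`COc1ccc(/C=C/c2cc(OC)cc(OC)c2/C=C/C(=O)c2ccc(Cl)c(Cl)c2)cc1`) gives 10.8 ug/mL and lies within the scatter of both. The three numbers therefore sit close together. Compound 4 (`CCCC(C)Oc1ccc(C(=O)/C=C/c2c(/C=C/c3ccc(OC)cc3)cc(OC)cc2OC)cc1`) keeps the shared core and changes one group, with 4-(1-methylbutoxy)phenyl in place of 3-methoxyphenyl on a carbonyl carbon. Among the compounds with values here, only one measured step touches that same place, the exchange of 3,4-dichlorophenyl for 3-methoxyphenyl (a 1.1-fold higher number from compound 2 to compound 3 (0.03 log units; within the scatter)), and it stayed within the scatter. A second hint comes from compound 1, which also has a chain joined through oxygen to that ring and gives 11.6 ug/mL in the same narrow range. Three compounds are a thin basis, and none of them carries the 1-methylbutoxy group itself. Even so, the groups tried at this place have so far left the numbers level, so no step beyond the scatter is expected in this assay for this change. The estimated step is correspondingly small (a 1.0-fold lower number from compound 3 to compound 4 (0.00 log units; within the scatter)). Compound 4 is expected at 11.5 ug/mL with an estimated range from 7 ug/mL to 19 ug/mL in this test.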

Compound 4, half-maximal inhibitory concentration: 11.1 ug/mL
For compound 4 the middle estimate is 1.0-fold (0.02 log units) above the measured one; the measured number falls inside the stated range.
By their numbers in this assay, from the lowest: compounds 2, 4, 1 and 3 (each within the scatter of the next).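

In this assay, the group on the carbonyl carbon can be 4-(1-methylbutoxy)phenyl, with 12 heavy atoms in place of the 8 of 3-methoxyphenyl, and the numbers remain within the scatter (a 1.0-fold lower number from compound 3 to compound 4 (0.02 log units; within the scatter)), as they do when it stands in place of 3,4-dichlorophenyl (a 1.0-fold higher number from compound 2 to compound 4 (0.01 log units; within the scatter)). Within the data shown here, the new compound also gives the first reading on the chain joined through oxygen to that ring: 1-methylbutyl in place of dodecyl, a branched group for a long straight chain, again gives a step within the scatter (a 1.0-fold lower number from compound 1 to compound 4 (0.02 log units; within the scatter)), so in these compounds this test does not separate the two chains. No measurement at hand explains why these numbers lie so close together.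

The groups shown at this place are all phenyl rings carrying chlorine atoms or chains joined through oxygen, so it remains open whether a ring bearing an amine or a carboxylic acid would also stay within the scatter. Also open, as far as these compounds go, is whether a chain ending in a hydroxyl group or a piperidine, in place of 1-methylbutyl on the oxygen, would give a step beyond it.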